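Amide in place of sulfone: outlook for compound 3

A few compounds are considered here, and "the series" means these few. Any claim that something is new, unique, unknown or untested is made for them only; others in the source may bear on it.

Among the measured compounds shown here, compound 2 `CC(C)(C)c1cc(NC(=O)Nc2ccc(Cl)cc2)n(-c2ccc(S(C)(=O)=O)cc2)n1` stands highest of the two numbers so far: in an assay on isolated protein for inhibition of STE20-like serine/threonine-protein kinase (Homo sapiens), read by thermal shift assay, tested at 10 uM (a lower number here means that the compound stabilises the target less, a higher number that the compound stabilises the target more against heat), compound 2 gives 5.2 degrees C, while its nearest neighbour compound 1 `CC(C)(C)c1cc(NC(=O)Nc2ccc(Cl)cc2)n(-c2ccc(C#N)cc2)n1` gives 1.6 degrees C. The only measured step, a number 3.6 degrees C higher from compound 1 to compound 2 (beyond the scatter), concerns the same aromatic carbon. Compound 3 `CC(C)C(=O)Nc1ccc(-n2nc(C(C)(C)C)cc2NC(=O)Nc2ccc(Cl)cc2)cc1` differs from compound 2 by (isopropylcarbonyl)amino in place of methylsulfonyl on an aromatic carbon. That earlier step bears on this one only loosely, as the entering group is neither of the two compared there, so a modest step in either direction, or none beyond the scatter, is plausible. Compound 3 is expected to give 3 degrees C (range 0.5 degrees C to 6 degrees C), an estimated step of a number 2.2 degrees C lower from compound 2 to compound 3 (beyond the scatter).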

Compound 3, shift of the target's melting temperature: 6.8 degrees C
Compound 3: the middle estimate sits 3.8 degrees C below what was measured; the measured number lies above the stated range.
By their numbers in this assay, from the lowest: compound 1; then compound 2; then compound 3.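

In this assay, the aromatic carbon para to a large group accepts (isopropylcarbonyl)amino, with a number 1.6 degrees C higher from compound 2 to compound 3 (beyond the scatter) in place of methylsulfonyl and a number 5.2 degrees C higher from compound 1 to compound 3 (beyond the scatter) in place of cyano. The top of the series thus moves from a sulfone to an amide that brings a hydrogen-bond donor, and compound 3 stands highest of the three. Nothing available explains this rise.

On these data alone, whether the rise follows the amide hydrogen or the isopropyl part remains open. An acetylamino group or a plain amine on the same carbon would help separate the two.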